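Hydroxy in place of nitro: notes on compound 3

The compounds below may be only part of what the source reports. "The series", "measured", "known", "first", "only" and "open" are said of these compounds alone.

In a functional assay on PC-3 cells (Homo sapiens) for antiproliferative activity, read by MTT assay, with a stated time of 48 h (on this read-out higher numbers stand for weaker inhibition and lower numbers for stronger inhibition), compound 1 (`C#CCOC(=O)/C(C)=C/CC/C(C)=C/CC/C(C)=C/CC[C@@H]1[C@@]2(C)CCC(=O)C(C)(C)[C@H]2CC[C@@]1(C)O`) gives 18900 nM as its half-maximal inhibitory concentration. Compound 2 (`C/C(=C\CC/C(C)=C/CC[C@@H]1[C@@]2(C)CCC(=O)C(C)(C)[C@H]2CC[C@@]1(C)O)CC/C=C(\C)C(=O)OCc1cn(-c2cccc([N+](=O)[O-])c2)nn1`) gives 24800 nM on the same read-out, and this number lies within the scatter of the value for compound 1, so the two stand level. Compound 3 (`C/C(=C\CC/C(C)=C/CC[C@@H]1[C@@]2(C)CCC(=O)C(C)(C)[C@H]2CC[C@@]1(C)O)CC/C=C(\C)C(=O)OCc1cn(-c2cccc(O)c2)nn1`) differs from compound 2 in one place: hydroxy in place of nitro on an aromatic carbon with hydroxy in place of nitro on an aromatic carbon, so that 3-nitrophenyl becomes 3-hydroxyphenyl. Within the data shown here, no measured pair shows this change. With compound 1 and compound 2 level, no step beyond the scatter is expected in this assay and no direction can be favoured. The estimated change is a 1.2-fold lower number from compound 2 to compound 3 (0.07 log units; within the scatter) and stays within the scatter. Compound 3 is expected at 21000 nM with an estimated range from 9000 nM to 48000 nM on this read-out.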

Compound 3, half-maximal inhibitory concentration: 6570 nM
Compound 3: the middle estimate sits 3.2-fold (0.50 log units) above what was measured; measured number outside the range, below it.
By their numbers in this assay, from the lowest: compound 3; then compounds 1 and 2 (each within the scatter of the next).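

In this assay, the substituent on the aromatic ring proves able to move the number: hydroxy in place of nitro gives a 3.8-fold lower number from compound 2 to compound 3 (0.58 log units; beyond the scatter). Compounds 1 and 2 stood level, which suggested no gain from the aryl-bearing group in place of ethynyl, yet 1-(3-hydroxyphenyl)-1H-1,2,3-triazol-4-yl in place of ethynyl gives a 2.9-fold lower number from compound 1 to compound 3 (0.46 log units; beyond the scatter), so across these compounds a gain over compound 1 appears only with hydroxy on that ring. No data on the cause of either step are at hand.

The compounds shown leave open whether the step follows from the arrival of hydroxy or from the departure of nitro. An amino or methoxy group at the same place, or a plain phenyl, would help separate the two readings.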